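This account rests on a few compounds, and the source may have more. Where it says the series, first, only, none or still open, it means among the compounds named here.

Working notes on the alkynyl side chain. In an ADME assay on NIH3T3 cells (Mus musculus) for cytotoxicity (a lower number here means that less compound is tolerated, a higher number that more compound is tolerated), compound 3, `CC(C)(C)CC#Cc1cc2c(Nc3ccc(OCc4cccc(F)c4)c(Cl)c3)ncnc2s1`, reads > 50 uM, which is a limit and not a number. Compound 1, `CCCN(CC#Cc1cc2ncnc(Nc3ccc(OCc4cccc(F)c4)c(Cl)c3)c2s1)CCC`, reads > 50 uM, which is likewise a limit. Together they make up (the limit of > 50 uM in this assay, at which 2 of the 3 values shown sit). Compound 2, `CN1CCN(CC#Cc2cc3c(Nc4ccc(OCc5cccc(F)c5)c(Cl)c4)ncnc3s2)CC1`, gives a true number of 6.7 uM.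

The next structure, compound 4, `CN(C)CC#Cc1cc2c(Nc3ccc(OCc4cccc(F)c4)c(Cl)c3)ncnc2s1`, has dimethylamino in place of tert-butyl on a saturated chain carbon bound to a triple-bonded carbon. The entering group holds nitrogen, as does the 4-methylpiperazin-1-yl of compound 2.

Within the data shown here, the one measured step that bears on this change is an at least 7.4-fold higher number from compound 2 to compound 3 (0.87 log units; beyond the scatter), where tert-butyl replaces 4-methylpiperazin-1-yl. Its size is only a lower bound, and the present change runs the opposite way. Compound 1 goes against a simple link between nitrogen at this carbon and a lower number, since its chain holds nitrogen there too, though its core is arranged differently. The expectation is therefore held loosely.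

The step expected is an at least 4.1-fold lower number from compound 3 to compound 4 (0.61 log units; beyond the scatter), a lower number beyond the scatter. For compound 4 the estimated value is 12 uM, with an expected range of 4 uM to 45 uM.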

Compound 4, half-maximal toxic concentration: 41 uM
The estimate for compound 4 lay 3.4-fold (0.53 log units) below the measured number; the measured number falls inside the stated range.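

In this assay the series now shows a 6.1-fold higher number from compound 2 to compound 4 (0.79 log units; beyond the scatter), so a nitrogen-bearing group on a saturated chain carbon bound to a triple-bonded carbon does not by itself bring the number down to the level of compound 2; dimethylamino and 4-methylpiperazin-1-yl part clearly here. The other new step, an at least 1.2-fold lower number from compound 3 to compound 4 (0.08 log units; that floor lies within the scatter), is only a floor, so it cannot be said that dimethylamino in place of tert-butyl lowers the number at all. That step stays a floor because compound 3 reads a limit and not a number: the limit of > 50 uM in this assay, at which 2 of the 4 values shown sit.

Open, on these data alone, is whether the low number of compound 2 goes with the ring of 4-methylpiperazin-1-yl or with its second nitrogen, which a morpholin-4-yl or a piperidin-1-yl on the same carbon would help to separate. Also open, as far as these compounds go, is how far compound 4 truly lies from compound 3, and whether these side chains would rank the same way on the core of compound 1.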